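A few compounds are considered here, and "the series" means these few. Any claim that something is new, unique, unknown or untested is made for them only; others in the source may bear on it.

Among the compounds with values here, in a functional assay on AN3-CA cells (Homo sapiens) for antiproliferative activity, read by MTT assay, with a stated time of 72 h (a lower number here means a stronger inhibitor, a higher number a weaker inhibitor), compound 2 `O=C(Nc1ccc(Cl)c(-c2nnc3c(Cl)cccn23)c1)c1cccc(Cl)c1` gives 68400 nM, the only outright number among the three measured compounds. Compound 1 `CS(=O)(=O)c1ccc(C(=O)Nc2ccc(Cl)c(-c3nnc4c(Cl)cccn34)c2)c(Cl)c1` gives only a limit, > 100000 nM. Compound 3 `O=C(Nc1ccc(Cl)c(-c2nnc3c(Cl)cccn23)c1)c1ccc(Cl)cc1` likewise gives only a limit, > 100000 nM. Within the data shown here, the single measured step that bears on the new compound is an at least 1.4-fold higher number from compound 2 to compound 3 (0.16 log units; that floor lies within the scatter), and the limit of > 100000 nM in this assay, at which 2 of the 3 values shown sit, leaves its true size open. Compound 4 `Cc1cc(Cl)ccc1C(=O)Nc1ccc(Cl)c(-c2nnc3c(Cl)cccn23)c1` differs from compound 2 by 4-chloro-2-methylphenyl in place of 3-chlorophenyl on a carbonyl carbon. Compound 4 is expected to show a step of a 1.6-fold higher number from compound 2 to compound 4 (0.21 log units; within the scatter), in line with an at least 1.4-fold higher number from compound 2 to compound 3 (0.16 log units; that floor lies within the scatter), which points to a weaker rather than a stronger inhibitor. Compound 4 is therefore estimated at 110000 nM, within 40000 nM to 300000 nM, with a real chance that only a limit is reported.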

Compound 4, half-maximal inhibitory concentration: > 100000 nM
Compound 4: only a limit was reported; the forecaster's own chance of this, stated with the estimate: 55%; the middle value does not contradict the limit.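

Putting 4-chloro-2-methylphenyl in place of 3-chlorophenyl on the carbonyl carbon gives an at least 1.4-fold higher number from compound 2 to compound 4 (0.16 log units; that floor lies within the scatter), so a second replacement at this place also shows no gain over compound 2. The step that adds methyl in place of hydrogen on an aromatic carbon cannot be read, as compound 3 and compound 4 each carry only a limit. The true size of these changes stays hidden, with most of the set now at one reading: the limit of > 100000 nM in this assay, at which 3 of the 4 values shown sit.

Still open, as far as these compounds go, is how an aminophenyl or a pyridyl group would read on the carbonyl carbon. Also open, from the compounds shown here alone, is whether any replacement there gives a clearly lower number than compound 2.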